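The source may report more compounds than this note shows. Statements on the series, on what has been measured and on what is new or still open speak of the compounds shown alone.

Of the compounds shown here, three sharing one core have been tested in a functional assay on HOS cells (Homo sapiens) for antiproliferative activity (a lower number here means a stronger inhibitor, a higher number a weaker inhibitor), so far. Compound 1 `Nc1n[nH]c(N)c1/N=N/c1ccccc1[N+](=O)[O-]` gives > 100000 nM as a limit of the assay and not as a number. Compound 2 `Nc1n[nH]c(N)c1/N=N/c1ccc([N+](=O)[O-])cc1` gives > 100000 nM as a limit too. Compound 3 `Nc1n[nH]c(N)c1/N=N/c1cccc(O)c1` likewise gives > 100000 nM as a limit. Compound 2 therefore has no number of its own and shares its place with the other two, the whole record being the limit of > 100000 nM in this assay, at which 3 of the 3 values shown sit, and nothing more. These results offer no measured step to reason from.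

Compound 4 `Nc1n[nH]c(N)c1/N=N/c1ccc(C(=O)O)cc1` has yet to be measured. It differs from compound 2 by carboxy in place of nitro on an aromatic carbon, para to a group of 9 heavy atoms, and the count of that exchange is carboxy in place of nitro on an aromatic carbon in full. Within the data shown here, with all three relatives resting at the limit of > 100000 nM in this assay, at which 3 of the 3 values shown sit, in this assay and no measured step to suggest otherwise, no change beyond the usual scatter is expected, in either direction. The estimated step is a number no higher from compound 2 to compound 4 (the limit leaves the size open) and so amounts to no real shift. Compound 4 is expected near 100000 nM with an estimated range from 40000 nM to 200000 nM and a limit of the assay rather than a number is the likely outcome.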

Compound 4, half-maximal inhibitory concentration: > 100000 nM
Compound 4 gave a limit, no number (the forecaster's own chance of this, stated with the estimate: 75%); the middle value sits exactly at the limit.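

In this assay, among these compounds, compound 4 stands at a limit of the assay, as compound 2 does, so no step between compound 2 and compound 4 can be read: the limit of > 100000 nM in this assay, at which 4 of the 4 values shown sit. The compounds shown leave open how carboxy compares with nitro on this core, and whether any change on the shared core gives a measurable value.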